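The source may report more compounds than this note shows. Statements on the series, on what has been measured and on what is new or still open speak of the compounds shown alone.

Measured so far in a physicochemical assay for lipophilicity, using the shake flask method, in phosphate buffer, measured as octanol-water partition, at pH 7.4; on this read-out lower numbers stand for lower lipophilicity and higher numbers for higher lipophilicity:
- compound 1 `COc1cc(-c2cc(C(=O)O)c3ccccc3n2)ccc1OCC(=O)Nc1ccccc1` gives 0.7
- compound 2 `COc1cc(-c2cc(C(=O)O)c3ccccc3n2)ccc1OCC(=O)Nc1ccccc1Cl` gives 1.6
- compound 3 `COc1cc(-c2cc(C(=O)O)c3ccccc3n2)ccc1OCC(=O)Nc1cccc(Cl)c1` gives 2.3

Compound 1 stands lowest of the three numbers in this assay. Its nearest neighbour is compound 2, with a number 0.90 log units higher from compound 1 to compound 2 (beyond the scatter); furthest away is compound 3, with a number 1.60 log units higher from compound 1 to compound 3 (beyond the scatter). Between the two chlorinated compounds themselves the shift is a number 0.70 log units higher from compound 2 to compound 3 (beyond the scatter).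

The unmeasured compound 4 `COc1cc(-c2cc(C(=O)O)c3ccccc3n2)ccc1OCC(=O)Nc1ccc(Cl)cc1` differs from compound 1 by chloro in place of hydrogen on an aromatic carbon, the chloro now sitting para to a large group. The two measured steps that bear on it are both chloro in place of hydrogen on the same phenyl of the amide, and both moved this assay upward beyond the scatter: a modest rise from compound 1 to compound 2 and a large rise from compound 1 to compound 3. The same replacement at the third open position of that ring is therefore expected to raise the number again, beyond the scatter, plausibly between the two measured steps. Compound 4 is thus estimated at 1.9, within 1.3 to 2.5, which would mean an expected step of a number 1.20 log units higher from compound 1 to compound 4 (beyond the scatter).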

Compound 4, distribution coefficient: 1.5
Compound 4: middle estimate off by 0.40 log units, on the high side, and the stated range covers the measured number.
By their numbers in this assay, from the lowest: compound 1; then compounds 4 and 2 (each within the scatter of the next); then compound 3.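

In this assay, chloro in place of hydrogen para to a large group gives a number 0.80 log units higher from compound 1 to compound 4 (beyond the scatter), so each of the three chlorinated compounds now has a step from compound 1 printed as beyond the scatter. The new result also separates the three placements: 4-chlorophenyl in place of 3-chlorophenyl gives a number 0.80 log units lower from compound 3 to compound 4 (beyond the scatter), whereas 4-chlorophenyl in place of 2-chlorophenyl gives a number 0.10 log units lower from compound 2 to compound 4 (within the scatter), so compound 4 and compound 2 cannot be told apart in this read-out and compound 3 alone stands highest of the four. No measurement at hand accounts for why the 3-chlorophenyl compound stands apart from the other two placements.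

The compounds shown leave open whether a fluoro, a methyl or a trifluoromethyl on the same phenyl would give the same order of placements as chloro does. They also leave open whether the chloro steps would keep their size if the carboxylic acid of the shared core gave way to an ester or a primary amide.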